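The source may report more compounds than this note shows. Statements on the series, on what has been measured and on what is new or still open speak of the compounds shown alone.

Compound 1, `COCc1noc([C@@H]2CC[C@@H](Nc3ncc4c(Br)nn(-c5ccc6ncccc6c5)c4n3)C2)n1`: 106 nM in an assay on isolated protein for inhibition of eIF-2-alpha kinase GCN2 (Homo sapiens); a higher number here means a weaker inhibitor, a lower number a stronger inhibitor
Compound 2, `COCCS(=O)(=O)N[C@@H]1CC[C@@H](Nc2ncc3c(Br)nn(-c4ccc5ncccc5c4)c3n2)C1`: 55 nM

Of the compounds shown here, two sharing one core have so far been measured in this assay. Compound 2 holds the lowest of the two numbers; its nearest neighbour is compound 1, and the step of a 1.9-fold lower number from compound 1 to compound 2 (0.28 log units; within the scatter) stays within the scatter, so the two are not told apart. That step swaps one group of eight heavy atoms for another on the saturated ring carbon.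

Compound 3, `CNC(=O)[C@@H]1CC[C@@H](Nc2ncc3c(Br)nn(-c4ccc5ncccc5c4)c3n2)C1`, has not yet been measured. It differs from compound 2 in one place: methylcarbamoyl in place of ((2-methoxyethyl)sulfonyl)amino on a saturated ring carbon. Within the data shown here, the only measured step that bears on this position is a 1.9-fold lower number from compound 1 to compound 2 (0.28 log units; within the scatter), and it was too small to stand out. Nothing else in the measured pair speaks to a smaller amide replacing the sulfonamide at this ring carbon, so the expectation rests on that single, flat step.

For compound 3 the expected step in this assay is a 1.5-fold higher number from compound 2 to compound 3 (0.16 log units; within the scatter), with nothing beyond the scatter foreseen. Compound 3 is therefore estimated at 80 nM, within a range from 25 nM to 260 nM.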

Compound 3, half-maximal inhibitory concentration: 21 nM
The estimate for compound 3 lay 3.8-fold (0.58 log units) above the measured number; measured number outside the range, below it.
By their numbers in this assay, from the lowest: compound 3; then compounds 2 and 1 (each within the scatter of the next).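

In this assay this saturated ring carbon now separates its substituents, which the flat step between the first two compounds could not show: methylcarbamoyl in place of ((2-methoxyethyl)sulfonyl)amino gives a 2.6-fold lower number from compound 2 to compound 3 (0.42 log units; beyond the scatter), a modest but real change. The same group also stands clear of the substituent of compound 1, with its five-membered aromatic ring, at a 5.0-fold lower number from compound 1 to compound 3 (0.70 log units; beyond the scatter), so the two larger groups of different kinds sit together while the smallest of the three sits apart from both. No measurement at hand accounts for this difference at the position.

Whether the gain belongs to the amide as such or merely to the shorter substituent remains open, since the compounds shown do not tell how a primary carboxamide, a dimethylamide or a carboxylic acid would stand on this ring carbon. Also open, as far as these compounds go, is whether an ethyl group or a longer chain on the amide nitrogen would keep the number of compound 3, and whether a reversed amide, with the carbonyl and nitrogen swapped, would behave alike.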